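Methoxy on the aryl ring: a small step to forecast

A few compounds are considered here, and "the series" means these few. Any claim that something is new, unique, unknown or untested is made for them only; others in the source may bear on it.

Measured so far:
compound 1, `CCn1c(SCC(=O)c2ccccc2)nnc1-c1ccc(OC)cc1`, 67%
compound 2, `O=C(CSc1nnc(-c2ccccc2)n1-c1ccccc1)c1ccccc1`, 64%

Both compounds were tested in a functional assay on the whole organism (strain albino) for inhibition, with Rattus norvegicus as the target, read by paw edema, with a stated time of 3 h, at a dose of 0.28 mmol/kg by the oral route (on this read-out higher numbers stand for more inhibition at the one dose given (going by the name of the read-out) and lower numbers for less inhibition), where each number tells how far the swelling of the paw was held back at the single dose. Compound 1 gives 67%, and compound 2 gives 64%. Compound 2 thus stands alongside compound 1, the two numbers lying within the usual scatter of each other, so no order between them can be read from these data. The two compounds differ in more than one place, so nothing about a single change can be drawn from their pair.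

Compound 3, `COc1ccc(-c2nnc(SCC(=O)c3ccccc3)n2-c2ccccc2)cc1`, has not yet been measured. It differs from compound 2 in one place: methoxy in place of hydrogen on an aromatic carbon. Compound 1 already carries this same methoxy group and sits at the same level as compound 2, so no step beyond the scatter is expected in this assay from adding it. The expected step from compound 2 is a number 2 percentage points higher from compound 2 to compound 3 (within the scatter). Compound 3 is therefore estimated at 66%, with a range from 54% to 78%.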

Compound 3, a percentage reported as inhibition, in the whole organism at one dose (the size of the read-out at that dose, not a potency): 58%
Estimate against measurement, compound 3: 8 percentage points above; low and high end bracket the measured number.
By their numbers in this assay, from the lowest: compounds 3, 2 and 1 (each within the scatter of the next).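

In this assay, putting methoxy in place of hydrogen on the aromatic ring, para to a large group, gives a number 6 percentage points lower from compound 2 to compound 3 (within the scatter), so this first direct reading of the change shows no effect that can be told apart from the scatter. The earlier pair differed in more than one place, whereas each change can now be read alone: phenyl in place of ethyl on the aromatic nitrogen gives a number 9 percentage points lower from compound 1 to compound 3 (within the scatter), so swapping these two groups also leaves the swelling read-out without a step beyond the scatter. Nothing available here explains either step.

The compounds shown leave open whether a different group on the same aromatic carbon, such as an amine or a carboxylic acid, would shift the inhibition by more than the scatter, since methoxy is the only group there besides hydrogen. They also leave open what a longer chain, such as butyl, would do on the aromatic nitrogen, where only ethyl and phenyl appear so far.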